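The source may report more compounds than this note shows. Statements on the series, on what has been measured and on what is new or still open speak of the compounds shown alone.

Working notes on the 3-hydroxyphenyl series. In a functional assay on DU-145 cells (Homo sapiens) for cytotoxicity, read by CCK-8 assay and cell counting, with a stated time of 2 days (a higher number here means a weaker inhibitor, a lower number a stronger inhibitor), compound 1 `Oc1cccc(-c2cc(-c3ccc(Cl)cc3)nc(-c3ccco3)c2)c1` gives 11400 nM, and compound 2 `Oc1cccc(-c2cc(-c3ccc(Cl)cc3)nc(-c3ccsc3)c2)c1` gives 11600 nM; the step of a 1.0-fold higher number from compound 1 to compound 2 (0.01 log units; within the scatter) is within the scatter. Compound 3 `Oc1cccc(-c2cc(-c3ccccc3)nc(-c3ccccc3Cl)c2)c1` gives 1480 nM, the lowest number of the three, with both other values beyond the scatter from it. Compound 4 `Oc1cccc(-c2cc(-c3ccccc3)nc(-c3ccc(Cl)cc3)c2)c1` differs from compound 3 by 4-chlorophenyl in place of 2-chlorophenyl on an aromatic carbon. Within the data shown here, no measured pair moves a chlorine around the same ring; the only step available changes a different ring and is within the scatter, so it gives no direction for this change. The expectation for a 1.2-fold higher number from compound 3 to compound 4 (0.09 log units; within the scatter) is therefore no shift beyond the scatter, but with wide uncertainty. Compound 4 is estimated at 1800 nM, between 500 nM and 8000 nM.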

Compound 4, half-maximal inhibitory concentration: 11200 nM
Beside the measured number, compound 4's estimate is 6.2-fold (0.79 log units) below it, and the stated range ends below it.
By their numbers in this assay, from the lowest: compound 3; then compounds 4, 1 and 2 (each within the scatter of the next).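

In this assay the placement of the chlorine decides the result: a 7.6-fold higher number from compound 3 to compound 4 (0.88 log units; beyond the scatter), with the same atoms joined differently. Once 4-chlorophenyl is present, the other aryl group makes no difference beyond the scatter: a 1.0-fold lower number from compound 2 to compound 4 (0.02 log units; within the scatter), and a 1.0-fold lower number from compound 1 to compound 4 (0.01 log units; within the scatter). Nothing available here accounts for the effect of moving the chlorine.

As far as these compounds go, it remains open whether 2-chlorophenyl would give the same shift alongside furan-2-yl or thiophen-3-yl. From the compounds shown here alone, it is also open whether a methoxy or an amine in place of the chlorine would retain the value of compound 3 1480 nM.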